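The source may hold more compounds than are shown below. What is called first, only, known or untested is meant among the compounds shown, and "the series" means these compounds.

Four compounds share one design: a core carrying an amino group, a saturated chain, and a hydroxycarbamoyl group at the end of that chain, all tested in a functional assay on PLC-PRF-5 cells (Homo sapiens) for inhibition, read by MTT assay, with a stated time of 72 h; a lower number here means a stronger inhibitor, a higher number a weaker inhibitor. Compound 1 `Nc1ncnc2c1c(-c1cnc3[nH]ccc3c1)nn2CCCCCCCCCC(=O)NO` gives 34200 nM in this assay. Compound 2 `Nc1ncnc2c1c(-c1cnc3[nH]ccc3c1)nn2CCCCCCC(=O)NO` reaches only > 50000 nM in this assay, which is a limit of the assay rather than a number. The step of an at least 1.4-fold lower number from compound 2 to compound 1 (0.16 log units; that floor lies within the scatter) corresponds to the change (3-(hydroxycarbamoyl)propyl in place of hydroxycarbamoyl on a saturated chain carbon, six bonds along the chain from an aromatic nitrogen); since one end of it sits at the limit of > 50000 nM in this assay, at which 2 of the 3 values shown sit, only a floor for this step is known. Compound 3 `Nc1nc2cc(-c3nn(CCCCCC(=O)NO)c4ncnc(N)c34)ccc2o1` carries a different core from compound 2, and the difference between the two cores is not broken down here. In this assay compound 3 shows > 50000 nM, again a limit of the assay and not a number. Compound 4 `Nc1nc2cc(-c3nn(CCCCCCCCC(=O)NO)c4ncnc(N)c34)ccc2o1` has not yet been measured in this assay. Compound 4 differs from compound 3 by 3-(hydroxycarbamoyl)propyl in place of hydroxycarbamoyl on a saturated chain carbon, five bonds along the chain from an aromatic nitrogen. Going by the values given here, this is the same kind of change as the one between compound 2 and compound 1, but the place is five bonds along the chain from an aromatic nitrogen rather than six. For compound 4 the expected step is an at least 1.1-fold lower number from compound 3 to compound 4 (0.04 log units; that floor lies within the scatter), resting on the measured at least 1.4-fold lower number from compound 2 to compound 1 (0.16 log units; that floor lies within the scatter), which is only a floor lying within the scatter. Compound 4 is therefore estimated at about 45000 nM, between 15000 nM and 150000 nM, with a fair chance that this assay again reports only a limit.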

Compound 4, half-maximal inhibitory concentration: 24000 nM
Compound 4: the middle estimate sits 1.9-fold (0.27 log units) above what was measured, and the stated range covers the measured number.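

Replacing hydroxycarbamoyl with 3-(hydroxycarbamoyl)propyl on the core of compound 3 gives an at least 2.0-fold lower number from compound 3 to compound 4 (0.31 log units; beyond the scatter) in this assay, and this step is only a floor, since one end of it rests on a limit of the assay. The same change on the core of compound 1 points the same way, but only the floor on the core of compound 3 clears the usual scatter, so neither step has a known size and the two cannot be told apart: the same change on two cores in this assay, an at least 1.4-fold lower number (0.16 log units; that floor lies within the scatter) from compound 2 to compound 1 and an at least 2.0-fold lower number (0.31 log units; beyond the scatter) from compound 3 to compound 4; the limit leaves it open whether they differ This shows that the change can lower the number on the core of compound 3, but it does not show that the two cores respond to an equal degree, and much of the series still rests on a single limit: the limit of > 50000 nM in this assay, at which 2 of the 4 values shown sit.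

The compounds shown leave open how the number moves with a longer chain, or with a carboxylic acid or a primary amide at the chain end in place of hydroxycarbamoyl. They also leave the two cores unranked, as compound 1 and compound 4 differ in more than one place and no pair shown changes the core alone.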